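The compounds below may be only part of what the source reports. "The series", "measured", "known", "first", "only" and "open" are said of these compounds alone.

In a functional assay on HCT-116 cells (Homo sapiens) for inhibition, read by MTT assay, with a stated time of 72 h; on this read-out higher numbers stand for weaker inhibition of growth and lower numbers for stronger inhibition of growth:

Compound 1 `NNC(=O)CCc1ccncc1-c1ccc2ccccc2c1`: > 30000 nM, a limit of the assay and not a number.
Compound 2 `O=C(O)CCNC(=O)/C=C/c1ccncc1-c1ccc2ccccc2c1`: "not determined" (no result reported).
Compound 3 `O=C(/C=C/c1ccncc1-c1ccc2ccccc2c1)N1CCOCC1`: 6040 nM.

For the measured compounds named here, compound 3 holds the only actual number, so there is no measured value to rank it against. Compound 4 `O=C(/C=C/c1ccncc1-c1ccc2ccccc2c1)NC1CC1` has cyclopropylamino in place of morpholin-4-yl on a carbonyl carbon. Going by the values given here, no measured pair shows a change of this kind, which leaves the expectation loosely anchored. The expected change in this assay is a 1.5-fold lower number from compound 3 to compound 4 (0.18 log units; within the scatter), with a slight lean towards stronger inhibition of growth but no step beyond the usual scatter. Compound 4 is expected at 4000 nM, with an estimated range of 1200 nM to 14000 nM.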

Compound 4, concentration for 50% growth inhibition: 6180 nM
Estimate against measurement, compound 4: 1.5-fold (0.19 log units) below, and the stated range covers the measured number.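

In this assay, cyclopropylamino in place of morpholin-4-yl on the carbonyl carbon gives a 1.0-fold higher number from compound 3 to compound 4 (0.01 log units; within the scatter), so at this position the exchange of the six-membered ring for the three-membered ring with a hydrogen-bond donor leaves the number within the scatter. 2-(Cyclopropylcarbamoyl)ethenyl in place of 2-(aminocarbamoyl)ethyl on an aromatic carbon gives an at least 4.8-fold lower number from compound 1 to compound 4 (0.68 log units; beyond the scatter). The value of compound 1, > 30000 nM, is a limit of the assay and not a number, so that step is only a bound: the limit of > 30000 nM in this assay, at which 1 of the 4 values shown sits.

Open, on these data alone, is whether piperazin-1-yl or a longer alkylamino chain on the carbonyl carbon would move the number beyond the scatter. Also open, as far as these compounds go, is how much of the step belongs to the ethenyl link and how much to the terminal group, as both change together.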